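Swapping the chain-end ring in a kinase-type inhibitor

The source may hold more compounds than are shown below. What is called first, only, known or untested is meant among the compounds shown, and "the series" means these compounds.

Compound 1 `COc1cc2c(Oc3ccc(NC(=O)c4nn(-c5ccccc5)c(=O)cc4C)cc3F)ccnc2cc1OCCCN1CCN(C)CC1` and compound 2 `COc1cc2c(Oc3ccc(NC(=O)c4nn(-c5ccccc5OC(F)(F)F)c(=O)cc4C)cc3F)ccnc2cc1OCCCN1CCCCC1` share one core and differ in two places. In a functional assay on NCI-H460 cells (Homo sapiens) for inhibition, read by MTT assay, with a stated time of 72 h (a higher number here means a weaker inhibitor, a lower number a stronger inhibitor), compound 1 gives 360 nM, and compound 2 gives 230 nM; these two numbers lie within the usual scatter of each other, so neither compound can be set apart from the other. Compound 3 `COc1cc2c(Oc3ccc(NC(=O)c4nn(-c5ccccc5OC(F)(F)F)c(=O)cc4C)cc3F)ccnc2cc1OCCCN1CCN(C)CC1` is built from compound 2 by a single change: 4-methylpiperazin-1-yl in place of piperidin-1-yl on a saturated chain carbon, three bonds along the chain from an oxygen on an aromatic ring. Going by the values given here, no measured pair isolates this change, so the step is expected to be small in this assay, with no direction beyond the scatter. For compound 3 the estimate in this assay is 260 nM, with a range from 120 nM to 550 nM. The step expected from compound 2 to compound 3 is therefore a 1.1-fold higher number from compound 2 to compound 3 (0.05 log units; within the scatter).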

Compound 3, half-maximal inhibitory concentration: 260 nM
For compound 3 middle estimate and measured number coincide at the digits printed; the measured number falls inside the stated range.
By their numbers in this assay, from the lowest: compounds 2, 3 and 1 (each within the scatter of the next).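

In this assay, going by these compounds alone, this pair isolates the chain-end ring for the first time: 3-(piperidin-1-yl)propyl gives way to 3-(4-methylpiperazin-1-yl)propyl with a 1.1-fold higher number from compound 2 to compound 3 (0.05 log units; within the scatter) and the change stays within the scatter. Trifluoromethoxy in place of hydrogen on an aromatic carbon can now be read alone too, with a 1.4-fold lower number from compound 1 to compound 3 (0.14 log units; within the scatter) and again within the scatter. Nothing available explains why either swap leaves the number within the scatter. As far as these compounds go, whether a morpholin-4-yl ring, a dimethylamino group or a longer chain would do the same remains open.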